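Adding a second chloro to the aryl ring of compound 3

The compounds below may be only part of what the source reports. "The series", "measured", "known", "first", "only" and "open" are said of these compounds alone.

Compound 1 `O=C(/C(=C/C1CCCCC1)CCl)c1ccccc1` gives 29000 nM in a functional assay on T47D cells (Homo sapiens) for inhibition, read by sulforhodamine B assay, with a stated time of 48 h; on this read-out lower numbers stand for stronger inhibition of growth and higher numbers for weaker inhibition of growth.
Compound 2 `O=C(/C(=C/c1ccccc1)CCl)c1ccccc1` gives 18000 nM in this assay.
Compound 3 `O=C(/C(=C/c1ccc(Cl)cc1)CCl)c1ccccc1` gives 17000 nM in this assay.

Compound 3 has the lowest of the three numbers, yet its gaps to compound 2 and compound 1 lie within the scatter, so no order among them can be read. Of the two measured steps, a 1.6-fold lower number from compound 1 to compound 2 (0.21 log units; within the scatter) replaced cyclohexyl with phenyl, and a 1.1-fold lower number from compound 2 to compound 3 (0.02 log units; within the scatter) added a chloro to that phenyl. The second step bears directly on compound 4 `O=C(/C(=C/c1ccc(Cl)cc1Cl)CCl)c1ccccc1`, which differs from compound 3 by chloro in place of hydrogen on an aromatic carbon. Because a 1.1-fold lower number from compound 2 to compound 3 (0.02 log units; within the scatter) stayed within the scatter, a similarly small change is expected for compound 4 in this assay, a 1.1-fold lower number from compound 3 to compound 4 (0.05 log units; within the scatter). Compound 4 is therefore estimated at 15000 nM, with a range from 7000 nM to 35000 nM.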

Compound 4, concentration for 50% growth inhibition: 6300 nM
Beside the measured number, compound 4's estimate is 2.4-fold (0.38 log units) above it; measured number outside the range, below it.
By their numbers in this assay, from the lowest: compound 4; then compounds 3, 2 and 1 (each within the scatter of the next).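

In this assay, within the data shown here, chloro in place of hydrogen on an aromatic carbon, ortho to a large group and meta to a chloro group, gives a 2.7-fold lower number from compound 3 to compound 4 (0.43 log units; beyond the scatter) and is the first step here beyond the scatter. By contrast a 1.1-fold lower number from compound 2 to compound 3 (0.02 log units; within the scatter) stays within the scatter, so the same exchange does not give the same result at both places on this ring. No measurement here accounts for that contrast.

As far as these compounds go, whether chloro itself matters at this position remains open. A methyl, a methoxy or an amine there could give a similar number or a very different one.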